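The compounds below may be only part of what the source reports. "The series", "measured", "known", "first", "only" and "open" are said of these compounds alone.

In an assay for inhibition of serine/threonine-protein kinase PLK2 (Homo sapiens), read by FRET and Z'-LYTE, with a stated time of 1 h (on this read-out higher numbers stand for weaker inhibition and lower numbers for stronger inhibition), the three measured compounds read as follows:

Compound 1 `CC[C@@H]1C(=O)N(C)c2cnc(-n3ccc4cc(C(N)=O)ccc43)nc2N1C1CCCC1` gives 28.5 nM.
Compound 2 `CCC1C(=O)N(C)c2cnc(Nc3ccc(S(=O)(=O)NCCO)cc3)nc2N1c1ccn(C)n1` gives 478 nM.
Compound 3 `CCCCNS(=O)(=O)c1ccc(Nc2ncc3c(n2)N(C2CCCC2)[C@H](CC)C(=O)N3C)cc1` gives 19.9 nM.

Compound 3 holds the lowest of the three numbers in this assay. Its value and that of compound 1 lie within the scatter of each other, so no order can be drawn between them. Compound 2 stands far away, with a number beyond the scatter above that of compound 3.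

Compound 4 `CC[C@@H]1C(=O)N(C)c2cnc(Nc3ccc(S(=O)(=O)Nc4ccccc4)cc3)nc2N1C1CCCC1` has not yet been measured. It differs from compound 3 in one place: phenyl in place of butyl on a sulfonamide nitrogen. For the measured compounds named here, no pair of measured compounds shows this change, so there is no step to lean on. The shared core, the cyclopentyl group and the sulfonamide linkage are kept; only the group on the sulfonamide nitrogen is exchanged. On that footing compound 4 is expected to stay close to compound 3, with a step of a 1.3-fold higher number from compound 3 to compound 4 (0.10 log units; within the scatter) that does not go beyond the scatter in either direction. The estimate for compound 4 in this assay is 25 nM, in a range from 8 nM to 80 nM.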

Compound 4, half-maximal inhibitory concentration: 54.4 nM
Estimate against measurement, compound 4: 2.2-fold (0.34 log units) below; measured number inside the range.
By their numbers in this assay, from the lowest: compounds 3, 1 and 4 (each within the scatter of the next, the first and the last beyond it); then compound 2.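

In this assay, for the compounds shown here, this is the first step that can be read at the sulfonamide nitrogen, and phenyl in place of butyl gives a 2.7-fold higher number from compound 3 to compound 4 (0.44 log units; beyond the scatter), a modest change but one beyond the scatter. The group on this nitrogen therefore does affect the number, although compound 4 still gives 54.4 nM with an aromatic ring of carbon only in this place. No measurement shown here explains the direction or the size of this step.

Going by these compounds, it remains open whether the difference follows from the loss of the butyl chain or from the arrival of the aromatic ring, which a cyclohexyl or benzyl group on the same nitrogen could help to separate. On these data alone, the effect of a shorter chain such as ethyl, a longer chain such as hexyl, or a butyl chain ending in an amine or a carboxylic acid also remains unknown.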